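The source may hold more compounds than are shown below. What is called first, only, known or untested is meant among the compounds shown, and "the series" means these compounds.

Measured so far:
compound 1 `C#CCNC1CCc2c(SCCc3ccc(Br)cc3)cccc21` — in an ADME assay on isolated protein for inhibition of Amine oxidase [flavin-containing] B (Homo sapiens) (on this read-out lower numbers stand for stronger inhibition and higher numbers for weaker inhibition), compound 1 gives 1250 nM
compound 2 `C#CCNC1CCc2c(SCCc3ccc(Cl)c(Cl)c3)cccc21` — in this assay compound 2 gives 2820 nM

Compound 1 holds the lowest number of the two measured; the nearest is compound 2, reached by the step of a 2.3-fold higher number from compound 1 to compound 2 (0.35 log units; beyond the scatter), a modest change from swapping one halogenated phenyl for another on the saturated chain carbon two bonds along the chain from the sulfur.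

Compound 3 `C#CCNC1CCc2c(SCCc3ccc(C(F)(F)F)cc3)cccc21` is not yet measured. It differs from compound 1 by trifluoromethyl in place of bromo on an aromatic carbon, the trifluoromethyl sitting on an aromatic carbon of the six-membered aromatic ring of carbon only, para to a large group. Among the measured compounds shown here, no measured step exchanges bromo for trifluoromethyl; the only comparable evidence is the halogen-pattern step from compound 1 to compound 2, which was modest. A step of similar or smaller size is therefore expected here, with no strong lean in either direction. Compound 3 is expected to give about 1800 nM, plausibly between 700 nM and 4500 nM. The expected step is a 1.4-fold higher number from compound 1 to compound 3 (0.16 log units; within the scatter).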

Compound 3, half-maximal inhibitory concentration: 8780 nM
Compound 3: middle estimate off by 4.9-fold (0.69 log units), on the low side, outside the stated range (above it).
By their numbers in this assay, from the lowest: compound 1; then compound 2; then compound 3.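

In this assay, trifluoromethyl in place of bromo on this aromatic carbon, para to a large group, gives a 7.0-fold higher number from compound 1 to compound 3 (0.85 log units; beyond the scatter) and so a larger step than a 2.3-fold higher number from compound 1 to compound 2 (0.35 log units; beyond the scatter) from the earlier halogen change. The read-out therefore depends clearly on which single group occupies this carbon, and among the compounds shown, bromo in compound 1 gives the lowest number. No available measurement accounts for the size of this step.

As far as these compounds go, whether a single chloro, a fluoro or a methoxy group at the same carbon would fall nearer to compound 1 or to compound 3 remains open. Also open is how much of the higher number for compound 2 belongs to each of its two chloro groups, as the shown compounds do not separate them.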